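A few compounds are considered here, and "the series" means these few. Any claim that something is new, unique, unknown or untested is made for them only; others in the source may bear on it.

Of the compounds shown here, three have so far been measured in a functional assay on MCF7 cells (Homo sapiens) for inhibition, read by sulforhodamine B assay, with a stated time of 72 h; on this read-out lower numbers stand for stronger inhibition of growth and higher numbers for weaker inhibition of growth. Compound 1 `NC(=O)/C=C/c1ccncc1-c1ccc2ccccc2c1` sits at the edge of what the assay can report: in this assay compound 1 gives > 10000 nM, which is a limit and not a number. Among the measured compounds shown here, compound 2 `CCOC(=O)/C=C/c1ccncc1-c1ccc2c(ccn2C)c1`, the only member with a numerical result, gives 8670 nM in this assay. Compound 3 `CNC(=O)/C=C/c1ccncc1-c1ccc2c(cnn2C)c1` also returns a limit: in this assay compound 3 gives > 10000 nM. For the measured compounds named here, compound 1 therefore stands at the limit of > 10000 nM in this assay, at which 2 of the 3 values shown sit, the place where the majority of the series rests, and no pair among the three differs in just one place, so no measured step is available to lean on.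

Compound 4 `NNC(=O)CCc1ccncc1-c1ccc2ccccc2c1` differs from compound 1 in a single place: 2-(aminocarbamoyl)ethyl in place of 2-carbamoylethenyl on an aromatic carbon. Nothing in the measured data points to a change in potency from such a change. With compound 1 at the limit of > 10000 nM in this assay, at which 2 of the 3 values shown sit, the step that the limit leaves unreadable from compound 1 to compound 4 is expected to be small and most likely none beyond the usual scatter. Compound 4 is estimated at 15000 nM in this assay, with a range of 5000 nM to 50000 nM, and it is expected that the assay will again report only a limit for it.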

Compound 4, concentration for 50% growth inhibition: > 10000 nM
Compound 4: no number, only a limit; the forecaster's own chance of this, stated with the estimate: 70%; the middle value lies beyond the limit too.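

In this assay compound 4 gives > 10000 nM, which is a limit and not a number. Compound 1 also rests on a limit, so no step can be read between compound 1 and compound 4. Compound 4 joins the majority of the series: the limit of > 10000 nM in this assay, at which 3 of the 4 values shown sit. The compounds shown leave open whether 2-(aminocarbamoyl)ethyl in place of 2-carbamoylethenyl changes growth inhibition at all.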